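Secoiridoid glycoside esters: phenethyl ester series on SK-BR-3

The source may report more compounds than this note shows. Statements on the series, on what has been measured and on what is new or still open speak of the compounds shown alone.

Measured so far:
Compound 1 `C/C=C1/[C@H](O[C@@H]2O[C@H](COC(C)=O)[C@@H](OC(C)=O)[C@H](OC(C)=O)[C@H]2OC(C)=O)OC=C(C(=O)OC)[C@H]1CC(=O)OCCC1CCCCC1` gives > 15000 nM in a functional assay on SK-BR-3 cells (Homo sapiens) for antiproliferative activity, read by MTT assay, with a stated time of 72 h; a higher number here means a weaker inhibitor, a lower number a stronger inhibitor; this is a limit of the assay, not a number.
Compound 2 `C/C=C1/[C@H](O[C@@H]2O[C@H](CO)[C@@H](O)[C@H](O)[C@H]2O)OC=C(C(=O)OC)[C@H]1CC(=O)OCCc1ccc(OC)c(OC)c1` gives > 15000 nM in this assay, again a limit.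
Compound 3 `C/C=C1/[C@H](O[C@@H]2O[C@H](COC(C)=O)[C@@H](OC(C)=O)[C@H](OC(C)=O)[C@H]2OC(C)=O)OC=C(C(=O)OC)[C@H]1CC(=O)OC` gives > 15000 nM in this assay, also a limit.

Compound 2 therefore stands only at the limit of this assay, and the two further values shown sit at the same limit (the limit of > 15000 nM in this assay, at which 3 of the 3 values shown sit). Among the compounds with values here, the single step between measured compounds, hydrogen in place of cyclohexylmethyl on a saturated chain carbon bound to an oxygen next to a carbonyl group, is a step that the two limits leave unreadable from compound 1 to compound 3 and so gives no readable size.

Compound 4 `C/C=C1/[C@H](O[C@@H]2O[C@H](CO)[C@@H](O)[C@H](O)[C@H]2O)OC=C(C(=O)OC)[C@H]1CC(=O)OCCc1ccccc1` differs from compound 2 by phenyl in place of 3,4-dimethoxyphenyl on a saturated chain carbon, two bonds along the chain from an oxygen next to a carbonyl group. Within the data shown here, no measured step bears directly on this change; the only measured step is unreadable, and every value shown is a limit. Nothing in the series points to activity appearing within range, so compound 4 is expected to stay near the limit, with an expected step that the limit leaves unreadable from compound 2 to compound 4. For compound 4 the estimate is 20000 nM, from 8000 nM to 60000 nM.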

Compound 4, half-maximal inhibitory concentration: 11000 nM
For compound 4 the middle estimate is 1.8-fold (0.26 log units) above the measured one; the range from low to high includes it.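

Within the data shown here, compound 4 is the first to give a number rather than a limit in this assay: 11000 nM. The other values shown remain limits of the assay, and the other step cannot be read: the limit of > 15000 nM in this assay, at which 3 of the 4 values shown sit. At this position, on a saturated chain carbon, two bonds along the chain from an oxygen next to a carbonyl group, phenyl in place of 3,4-dimethoxyphenyl gives an at least 1.3-fold lower number from compound 2 to compound 4 (0.13 log units; that floor lies within the scatter), so this change is not shown to lower the number beyond the scatter, though the true step could be larger.

Open, as far as these compounds go, is whether a phenyl bearing one methoxy group, a 4-fluorophenyl, or a longer chain in place of phenethyl would give a number further from the limit. Also open, from the compounds shown here alone, is how far the number for the phenethyl ester depends on the free sugar hydroxyls.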